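The source may hold more compounds than are shown below. What is called first, only, known or untested is meant among the compounds shown, and "the series" means these compounds.

Three compounds were tested in a functional assay on SW-620 cells (Homo sapiens) for inhibition, read by MTT assay, with a stated time of 48 h; a lower number here means a stronger inhibitor of growth, a higher number a weaker inhibitor of growth. Within the data shown here, compound 1 `O=[N+]([O-])c1ccc(-c2cc(-c3ccc(F)cc3)n[nH]2)cc1` gives 18100 nM, and compound 2 `O=[N+]([O-])c1ccc(-c2cc(-c3ccc(Br)cc3)n[nH]2)cc1` gives 28600 nM; the one measured step between them, a 1.6-fold higher number from compound 1 to compound 2 (0.20 log units; within the scatter), is a small one. Compound 3 `Nc1ccc(-c2cc(-c3ccccc3)n[nH]2)cc1` gives 25400 nM, the second highest of the three numbers, and both of its gaps to the others fall within the scatter. Compound 4 `COc1ccccc1-c1cc(-c2ccc(N)cc2)[nH]n1` differs from compound 3 by methoxy in place of hydrogen on an aromatic carbon. Among the measured compounds shown here, no measured step touches this kind of change, and the single measured step lies on another part of the structure and stayed within the scatter. The expected step is therefore a 1.0-fold lower number from compound 3 to compound 4 (0.01 log units; within the scatter), nothing beyond the scatter. Compound 4 is thus estimated at 25000 nM, with a range from 9000 nM to 70000 nM.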

Compound 4, concentration for 50% growth inhibition: 21100 nM
The estimate for compound 4 lay 1.2-fold (0.07 log units) above the measured number; measured number inside the range.
By their numbers in this assay, from the lowest: compounds 1, 4, 3 and 2 (each within the scatter of the next).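

The step of a 1.2-fold lower number from compound 3 to compound 4 (0.08 log units; within the scatter) shows that methoxy can sit on this aromatic carbon, ortho to a large group, with no change that stands out from the scatter. The earlier step only exchanged one halogen for another, whereas this one adds a group where there was only hydrogen. Nothing available here bears on this result.

On these data alone, whether a hydroxyl, an ethoxy or a dimethylamino group at this same position would shift the number beyond the scatter remains open.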